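Diaryl urea series: removing the aminopyrimidine from the ether

This account rests on a few compounds, and the source may have more. Where it says the series, first, only, none or still open, it means among the compounds named here.

Three measured compounds share a diaryl urea with a trifluoromethyl or ethyl substituent on one aryl ring and an aryl ether on the other. Compound 1 `CNc1cc(Oc2ccc(NC(=O)Nc3cccc(C(F)(F)F)c3)c(F)c2)ncn1` gives 63 nM in an assay on isolated protein for inhibition of serine/threonine-protein kinase TNNI3K (Homo sapiens); a higher number here means a weaker inhibitor, a lower number a stronger inhibitor. Compound 2 `Nc1cc(Oc2ccc(NC(=O)Nc3cccc(C(F)(F)F)c3)cc2)ncn1` gives 25 nM in this assay and stands at the lowest of the three numbers; compound 1 lies higher by a gap beyond the usual scatter, and compound 3 `CCc1cccc(NC(=O)Nc2ccc(Oc3cc(NC)ncn3)cc2)c1`, which gives 200 nM in this assay, lies furthest off, also beyond the scatter. No pair among these three differs in only one place, so no single step is read from them.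

Compound 4 `O=C(Nc1ccc(Oc2ccncc2)cc1)Nc1cccc(C(F)(F)F)c1` is the next point. It differs from compound 2 in one place: pyridin-4-yl in place of 6-aminopyrimidin-4-yl on an oxygen on an aromatic ring. The group that leaves carries the only hydrogen-bond donor of that ring; what enters carries none. Within the data shown here, no measured pair in this set isolates such a change, so the direction of the step rests on expectation alone. The step of a 12-fold higher number from compound 2 to compound 4 (1.08 log units; beyond the scatter) is expected to be a loss in potency beyond the scatter, with wide uncertainty. Compound 4 is therefore estimated at 300 nM, with a range from 60 nM to 1500 nM.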

Compound 4, half-maximal inhibitory concentration: 50 nM
Estimate against measurement, compound 4: 6.0-fold (0.78 log units) above; measured number outside the range, below it.
By their numbers in this assay, from the lowest: compounds 2, 4 and 1 (each within the scatter of the next, the first and the last beyond it); then compound 3.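

In this assay, among these compounds, the first single-place step reads a 2.0-fold higher number from compound 2 to compound 4 (0.30 log units; within the scatter) for pyridin-4-yl in place of 6-aminopyrimidin-4-yl on an oxygen on an aromatic ring. At this position, in this pair, the hydrogen-bond donor of 6-aminopyrimidin-4-yl is therefore not needed to stay within the scatter, and a ring with a single hetero atom serves as well as one with two, though the finding rests on this one pair. No measurement in hand bears on why the two groups read alike.

Open, on these data alone, is whether a plain phenyl ring with no ring nitrogen, a pyridin-3-yl ring or a pyridin-4-yl ring carrying an amine would stay in the same range on this oxygen, which would show how much of the hetero ring matters at all. Also open, as far as these compounds go, is whether the same exchange gives a comparable step on the core of compound 1, with its fluorine, or of compound 3, with its ethyl group in place of trifluoromethyl.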